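Aryl swap at the ring carbon and HDAC6 inhibition

This account rests on a few compounds, and the source may have more. Where it says the series, first, only, none or still open, it means among the compounds named here.

Compound 1: `O=C(NO)c1ccc(NCc2nc(-c3cc4ccccc4s3)nn2-c2ccccc2)cc1` gives 65.5%
Compound 2: `Cc1ccc(-c2nc(CNc3ccc(C(=O)NO)cc3)n(-c3ccccc3)n2)s1` gives 79.7%

For the measured compounds named here, in an assay on Sf9 cells for inhibition of protein deacetylase HDAC6 (Homo sapiens), read by fluorescence, with a stated time of 40 min, tested at 100 nM (a lower number here means less inhibition, a higher number more inhibition at the concentration tested (going by the name of the read-out)), compound 2 stands highest of the two numbers, and the only measured step, a number 14.2 percentage points higher from compound 1 to compound 2 (beyond the scatter), shows that exchanging the aryl group on that carbon moves the read-out by a modest amount. Compound 3 is `Cc1ccccc1-c1nc(CNc2ccc(C(=O)NO)cc2)n(-c2ccccc2)n1`. It differs from compound 2 as follows: 2-methylphenyl in place of 5-methylthiophen-2-yl on an aromatic carbon. Going by the values given here, no measured step covers a thiophene-to-phenyl exchange, so the expectation rests on the size of that single aryl swap. A shift of similar size in either direction is plausible; a small drop is expected, a number 9.7 percentage points lower from compound 2 to compound 3 (within the scatter), giving compound 3 an estimated 70% with a range from 50% to 88%.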

Compound 3, a percentage reported as inhibition, at one concentration (the size of the read-out at that concentration, not a potency): 53.2%
Compound 3: the middle estimate sits 16.8 percentage points above what was measured; the measured number falls inside the stated range.
By their numbers in this assay, from the lowest: compound 3; then compound 1; then compound 2.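

In this assay, the 2-methylphenyl group gives the lowest number of the three aryl groups on this ring carbon, with a number 26.5 percentage points lower from compound 2 to compound 3 (beyond the scatter) and a number 12.3 percentage points lower from compound 1 to compound 3 (beyond the scatter), both beyond the usual scatter. Among these compounds, both sulfur-containing groups stand above this six-membered aromatic ring of carbon only. Nothing available explains the drop. From the compounds shown here alone, whether the lower number goes with the six-membered ring itself or with its methyl group stays open. So does what a non-aromatic group on this carbon, such as an amine, would give.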